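The source may hold more compounds than are shown below. What is called first, only, known or untested is meant among the compounds shown, and "the series" means these compounds.

Measured so far:
compound 1, `CCC(C)(C)c1ccc(S(=O)(=O)Nc2ncnc(OCCOc3ncc(Br)cn3)c2-c2ccc(C)cc2)cc1`: < 0.001 nM
compound 2, `CSc1cnc(OCCOc2ncnc(NS(=O)(=O)c3ccc(C(C)(C)C)cc3)c2-c2ccc(C(C)C)cc2)nc1`: 1.2 nM

In an assay on cells (Endothelial cell) for binding affinity to Endothelin-1 receptor (Sus scrofa) (on this read-out higher numbers stand for weaker inhibition and lower numbers for stronger inhibition), compound 1 gives only a limit, < 0.001 nM, and not a number; see (the limit of < 0.001 nM in this assay, at which 1 of the 2 values shown sits). Among the measured compounds shown here, compound 2 gives 1.2 nM in this assay, the only number in the set. Compound 3, `CSc1cnc(OCCOc2ncnc(NS(=O)(=O)c3ccc(C(C)(C)C)cc3)c2-c2cccs2)nc1`, is not yet measured. It differs from compound 2 by thiophen-2-yl in place of 4-isopropylphenyl on an aromatic carbon, on an aromatic carbon of a six-membered aromatic ring with 2 nitrogen. For the measured compounds named here, no measured pair isolates this change. The step is expected to be modest and toward weaker inhibition, a 4.2-fold higher number from compound 2 to compound 3 (0.62 log units; beyond the scatter). For compound 3 the estimate is 5 nM, with an expected range from 1 nM to 30 nM.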

Compound 3, half-maximal inhibitory concentration: 0.89 nM
Beside the measured number, compound 3's estimate is 5.6-fold (0.75 log units) above it; measured number outside the range, below it.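

In this assay, thiophen-2-yl in place of 4-isopropylphenyl gives a 1.3-fold lower number from compound 2 to compound 3 (0.13 log units; within the scatter). On this aromatic carbon, a five-membered aromatic ring with 1 hetero atom and 5 heavy atoms therefore reads alike with a six-membered aromatic ring of carbon only and 9 heavy atoms. Nothing measured here bears on why the two compounds read alike. Still open, from the compounds shown here alone, is whether an aminomethyl group or a carboxylic acid on this same carbon would read alike too. Also open, going by these compounds, is whether thiophen-2-yl would hold this level alongside the other groups of compound 1.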